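Cutting Ethyl from the Amine Chain of Compound 1

The compounds below may be only part of what the source reports. "The series", "measured", "known", "first", "only" and "open" are said of these compounds alone.

Among the measured compounds shown here, in a functional assay on A549 cells (Homo sapiens) for antiproliferative activity, read by WST assay, with a stated time of 72 h (a lower number here means that less compound is needed, a higher number that more compound is needed for the effect), compound 1 `CCCCCCNCC(=O)Nc1ccc(/C(N)=N/O)cc1` gives 658000 nM, the only actual number available so far. Compound 2 `CCCCCCNCCCC(=O)Nc1ccc(/C(N)=N/O)cc1` returns no number in this assay. Its result is a limit, > 1000000 nM. Compound 1 is therefore the one reference point with a number to measure against.

Compound 3 `CCCCNCC(=O)Nc1ccc(/C(N)=N/O)cc1` keeps the core of compound 1 and differs only in its chain: hydrogen in place of ethyl on a saturated chain carbon, four bonds along the chain from an amine nitrogen. Hydrogen stands in place of ethyl on a saturated chain carbon, four bonds along the chain from an amine nitrogen. For the measured compounds named here, no step between measured compounds is available to size this change, so any expectation remains loose. In this assay a small step is expected, either within the scatter or modestly toward more compound being needed, and the reading could end as a limit rather than a number. The expected change is a 1.3-fold higher number from compound 1 to compound 3 (0.11 log units; within the scatter). For compound 3 the estimated value is 850000 nM, with an expected range from 400000 nM to 1500000 nM.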

Compound 3, half-maximal effective concentration: 395000 nM
Beside the measured number, compound 3's estimate is 2.2-fold (0.33 log units) above it; the whole stated range lies above it.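

The step of a 1.7-fold lower number from compound 1 to compound 3 (0.22 log units; within the scatter) in this assay gives this change its first measured size: hydrogen in place of ethyl on a saturated chain carbon, four bonds along the chain from an amine nitrogen, leaves the reading within the scatter. At this place, then, the loss of two carbons has no effect that can be told apart from repeat-measurement noise, and compound 3 still gives a number rather than a limit, so the step can be read directly. Compound 2 is the only compound shown whose result is a limit and not a number: the limit of > 1000000 nM in this assay, at which 1 of the 3 values shown sits.

The compounds shown leave open whether a longer chain, or an amine or a carboxylic acid on this carbon, would move the reading beyond the scatter. They also leave open whether hydrogen in place of ethyl at the same place on the chain of compound 2 would yield a number, since this single step speaks only for the pair that it joins.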